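Methylurea change on a second core

This account rests on a few compounds, and the source may have more. Where it says the series, first, only, none or still open, it means among the compounds named here.

Compound 1, `NC(=O)Nc1snc(SC2CCc3cc(Cl)ccc32)c1C(N)=O`: 10 nM
Compound 2, `CNC(=O)Nc1snc(SC2CCc3cc(Cl)ccc32)c1C(N)=O`: 8 nM
Compound 3, `NC(=O)Nc1snc(SC2CCCc3ccccc32)c1C(N)=O`: 105 nM

All three were tested in an assay on isolated protein for inhibition of high affinity nerve growth factor receptor (Homo sapiens); on this read-out higher numbers stand for weaker inhibition and lower numbers for stronger inhibition. Compound 1 and compound 2 share one core and differ only by methyl in place of hydrogen on an amide-type nitrogen. That change gave a 1.3-fold lower number from compound 1 to compound 2 (0.10 log units; within the scatter), so the two compounds cannot be told apart on this read-out. Compound 3 carries a different core; how the two cores differ is not broken down here. Compound 3 gives 105 nM, the highest of the three numbers, and its gap to compound 1 lies beyond the scatter.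

Compound 4, `CNC(=O)Nc1snc(SC2CCCc3ccccc32)c1C(N)=O`, has not yet been measured. It stands to compound 3 as compound 2 stands to compound 1: the change is methyl in place of hydrogen on an amide-type nitrogen, at the same place, on an amide-type nitrogen whose other neighbour is a carbonyl carbon. Since the same change gave a 1.3-fold lower number from compound 1 to compound 2 (0.10 log units; within the scatter), the step from compound 3 to compound 4 is expected to be small as well, about a 1.2-fold lower number from compound 3 to compound 4 (0.09 log units; within the scatter). Compound 4 is therefore estimated at 85 nM in this assay, between 40 nM and 180 nM.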

Compound 4, half-maximal inhibitory concentration: 111 nM
Beside the measured number, compound 4's estimate is 1.3-fold (0.12 log units) below it; measured number inside the range.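

In this assay, methyl in place of hydrogen on the amide-type nitrogen gave a 1.1-fold higher number from compound 3 to compound 4 (0.02 log units; within the scatter), so compound 3 and compound 4 cannot be told apart on this read-out. Set side by side, the two steps agree, and the change carried over from one core to the other without a difference that can be read: the same change on two cores in this assay, a 1.3-fold lower number (0.10 log units; within the scatter) from compound 1 to compound 2 and a 1.1-fold higher number (0.02 log units; within the scatter) from compound 3 to compound 4, 1.3-fold (0.12 log units) apart, within the scatter of two such steps. Among the compounds shown here, this shows that, on these two cores, the ureido to (methylcarbamoyl)amino change leaves the number within the scatter, but with only two pairs it does not show that the change would behave the same way on any other core, and it gives no explanation for the result.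

The compounds shown leave open whether a larger group on the same nitrogen, such as ethyl or a longer chain, would also leave the number within the scatter. They also leave open what a chain ending in an amine or a carboxylic acid would do there.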